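The source may report more compounds than this note shows. Statements on the series, on what has been measured and on what is new or still open speak of the compounds shown alone.

In a functional assay on NCI-H460 cells (Homo sapiens) for cytotoxicity, read by resazurin assay, with a stated time of 72 h (on this read-out lower numbers stand for stronger inhibition and higher numbers for weaker inhibition), two compounds have been measured so far. Compound 1 (`COc1cc(/C=C/C(=O)OCCCO[N+](=O)[O-])ccc1OCCCO[N+](=O)[O-]`) reads > 50000 nM, which is a limit of the assay and not a number. Among the measured compounds shown here, compound 2 (`O=C(/C=C/c1ccc(O)c(O)c1)OCc1c(-c2ccccc2)no[n+]1[O-]`) gives 2540 nM, the only actual number available, so there is no measured step against which to judge it. Compound 3 (`COc1cc(/C=C/C(=O)OCc2c(-c3ccccc3)no[n+]2[O-])ccc1O`) has not yet been measured. It differs from compound 2 by a single change, methyl in place of hydrogen on an oxygen on an aromatic ring, which turns 3,4-dihydroxyphenyl into 4-hydroxy-3-methoxyphenyl (methyl in place of hydrogen on an oxygen on an aromatic ring). For the measured compounds named here, no measured step shows what this change does in this assay, so only a modest loss of inhibition is expected, possibly not much beyond the scatter. The expected change is a 1.8-fold higher number from compound 2 to compound 3 (0.25 log units; within the scatter). The estimate for compound 3 is 4500 nM, within an expected range of 1500 nM to 14000 nM.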

Compound 3, half-maximal inhibitory concentration: 7030 nM
Estimate against measurement, compound 3: 1.6-fold (0.19 log units) below; the measured number falls inside the stated range.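

Methyl in place of hydrogen on an oxygen on an aromatic ring gives a 2.8-fold higher number from compound 2 to compound 3 (0.44 log units; beyond the scatter) in this assay, the first measured step at this position, and it shows that inhibition responds to the change from hydroxy to methoxy. The step is modest, and compound 3 still gives an actual number rather than a limit, so 4-hydroxy-3-methoxyphenyl keeps measurable inhibition in this series. Nothing shown here accounts for why the number rises.

From the compounds shown here alone, whether the remaining hydroxy on the ring responds in the same way stays open. So does what an ethoxy group or an amine at this position would do, and whether the step holds on any other core.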